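Working notes on the shared core: compound 3 to compound 4

The source may report more compounds than this note shows. Statements on the series, on what has been measured and on what is new or still open speak of the compounds shown alone.

Compound 1 `Cc1nc(Nc2ccccc2)sc1C(=O)/C=C/c1ccc(Cl)cc1` in a functional assay on PC-3 cells (Homo sapiens) for cytotoxicity, read by MTT assay (a higher number here means a weaker inhibitor, a lower number a stronger inhibitor), gives > 25000 nM, a limit of the assay.
Compound 2 `Cc1ccc(Nc2nc(C)c(C(=O)/C=C/c3ccc(Cl)cc3)s2)cc1` in this assay gives > 25000 nM, a limit of the assay.
Compound 3 `Cc1nc(Nc2ccc(Cl)cc2)sc1C(=O)/C=C/c1ccc(Cl)cc1` in this assay gives > 25000 nM, a limit of the assay.

Compound 3 thus stands only at a limit, and the two further values shown are limits as well, all three sitting at the limit of > 25000 nM in this assay, at which 3 of the 3 values shown sit. Compound 4 `Cc1nc(Nc2ccc(Cl)c(Cl)c2)sc1C(=O)/C=C/c1ccc(Cl)cc1` differs from compound 3 by chloro in place of hydrogen on an aromatic carbon. The measured steps on the same ring are a step that the two limits leave unreadable from compound 1 to compound 2, a step that the two limits leave unreadable from compound 1 to compound 3 and a step that the two limits leave unreadable from compound 2 to compound 3, none readable in size because the limit of > 25000 nM in this assay, at which 3 of the 3 values shown sit, holds every value shown. No direction for the new chloro step can be drawn from them. The expected step is therefore a step that the limit leaves unreadable from compound 3 to compound 4, most probably ending again at a limit rather than a number. Compound 4 is estimated at 40000 nM, within 15000 nM to 120000 nM.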

Compound 4, half-maximal inhibitory concentration: > 25000 nM
Compound 4: only a limit was reported (the forecaster's own chance of this, stated with the estimate: 85%); the middle value lies beyond the limit too.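

Compound 4, like compound 1, compound 2 and compound 3, stands only at a limit of the assay, so no step among them can be read: the limit of > 25000 nM in this assay, at which 4 of the 4 values shown sit.

The compounds shown leave open whether any change on the phenyl ring gives a readable number in this assay.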